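The source may hold more compounds than are shown below. What is called first, only, known or untested is meant among the compounds shown, and "the series" means these compounds.

Of the compounds shown here, three sharing one core have been tested so far. Compound 1 `NS(=O)(=O)c1ccc(N2N=C(c3cccc(O)c3)C[C@H]2c2ccccc2)cc1` is the plain parent; in a functional assay on the whole organism (strain Wistar albino) for inhibition, with Rattus norvegicus as the target, read by paw edema, with stated times of 30 min and 3 h, at a dose of 0.05 mmol/kg (a lower number here means less inhibition, a higher number more inhibition at the dose given (going by the name of the read-out)), compound 1 gives 35.8%. Compound 2 `NS(=O)(=O)c1ccc(N2N=C(c3cccc(O)c3)C[C@H]2c2ccc(Cl)cc2)cc1` carries a chloro in place of hydrogen and gives 19.2%, a change of a number 16.6 percentage points lower from compound 1 to compound 2 (beyond the scatter). Compound 3 `Cc1ccc([C@@H]2CC(c3cccc(O)c3)=NN2c2ccc(S(N)(=O)=O)cc2)cc1` carries a methyl instead and gives 64.7%, the highest of the three numbers: a number 28.9 percentage points higher from compound 1 to compound 3 (beyond the scatter) and a number 45.5 percentage points higher from compound 2 to compound 3 (beyond the scatter).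

Compound 4 `NS(=O)(=O)c1ccc(N2N=C(c3cccc(O)c3)C[C@H]2c2ccccc2O)cc1` has not been measured. The change from compound 3 is 2-hydroxyphenyl in place of 4-methylphenyl on a saturated ring carbon. Within the data shown here, no measured step puts a hydroxyl on this ring, so the only guide is indirect: compound 1, lacking the methyl, sits well below compound 3, and compound 2, with a chloro there, sits lower still. A ring bearing a hydroxyl is a third kind of group, and nothing in the three measurements suggests it would recover the gain seen with methyl. The estimate for compound 4 is therefore a drop, a number 29.7 percentage points lower from compound 3 to compound 4 (beyond the scatter), landing near the value of the parent, and the spread is wide. Compound 4 is expected to give 35%, within 15% to 55%.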

Compound 4, a percentage reported as inhibition, in the whole organism at one dose (the size of the read-out at that dose, not a potency): 35.4%
Estimate against measurement, compound 4: 0.4 percentage points below, and the stated range covers the measured number.
By their numbers in this assay, from the lowest: compound 2; then compounds 4 and 1 (each within the scatter of the next); then compound 3.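

In this assay, among these compounds, adding a hydroxy to the phenyl ring of compound 1 to give the 2-hydroxyphenyl group leaves no difference that stands out from the scatter, with a number 0.4 percentage points lower from compound 1 to compound 4 (within the scatter), so this is the first change on this ring that does not move the reading. Set against the two other groups at this position, the 2-hydroxyphenyl compound shows a number 29.3 percentage points lower from compound 3 to compound 4 (beyond the scatter) and a number 16.2 percentage points higher from compound 2 to compound 4 (beyond the scatter), which means it keeps none of the gain seen with 4-methylphenyl and none of the loss seen with 4-chlorophenyl. Nothing available explains why these groups give different readings.

On these data alone, what stays open is whether the flat result belongs to the hydroxy itself or to its place on the ring, since the chloro and methyl groups sit at a different ring position, and a 4-hydroxyphenyl or 2-methylphenyl group would separate those two questions. Also open, as far as these compounds go, is whether the high reading of compound 3 is special to methyl, which a 4-ethylphenyl or 4-aminophenyl group would test.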